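Fluoro for chloro: expected tolerability in liver cells

The compounds below may be only part of what the source reports. "The series", "measured", "known", "first", "only" and "open" are said of these compounds alone.

Compound 2 `O=C(NO)c1ccccc1Cl` is the starting point for the present step. In an ADME assay on Huh-7 cells (Homo sapiens) for cytotoxicity, read by MTT assay, with a stated time of 72 h (a higher number here means that more compound is tolerated, a lower number that less compound is tolerated), compound 2 gives 330000 nM. Compound 3 `Cc1cccc(C(=O)NO)c1` carries a methyl on the shared core in place of the chloro, and in this assay compound 3 gives 340000 nM, a number that sits within the scatter of the value of compound 2, so the two cannot be told apart. Compound 1 `CONC(=O)c1ccccc1OC`, with a methoxy on the shared core and a methyl on the amide nitrogen, reaches only the limit of this assay, > 800000 nM, and no number. Of the three values shown, one is therefore a limit of > 800000 nM in this assay, at which 1 of the 3 values shown sits, and two are numbers that agree with each other.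

The next compound, compound 4 `O=C(NO)c1ccccc1F`, differs from compound 2 by fluoro in place of chloro on an aromatic carbon. Within the data shown here, no measured step of this kind exists within the set, so the direction rests on the structural change alone. Given that the methyl of compound 3 and the chloro of compound 2 give indistinguishable numbers, the exchange of one halogen for another is expected to move the value little; a step from compound 2 to compound 4 of a 1.2-fold higher number from compound 2 to compound 4 (0.08 log units; within the scatter) is expected, none beyond the scatter. Compound 4 is therefore estimated at 400000 nM, with a plausible range from 200000 nM to 800000 nM.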

Compound 4, half-maximal cytotoxic concentration: 300000 nM
Estimate against measurement, compound 4: 1.3-fold (0.12 log units) above, and the stated range covers the measured number.
By their numbers in this assay, from the lowest: compounds 4, 2 and 3 (each within the scatter of the next). At a limit, above all of these: compound 1.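

In this assay, among these compounds, fluoro in place of chloro on an aromatic carbon, ortho to a group of 4 heavy atoms, gives a 1.1-fold lower number from compound 2 to compound 4 (0.04 log units; within the scatter), and this is the first step between two compounds that differ in one place. Among the compounds shown here, no two of the earlier compounds formed such a pair, so this position had no direct reading until now; it shows that these two halogens cannot be told apart here, with compound 2 and compound 4 standing as equivalent within the scatter. The reading covers this one exchange at this one position and supports no wider trend across the series.

Whether an amine, a carboxylic acid, a longer chain or any other group that is not a halogen would move the number beyond the scatter at this position remains open, as the compounds shown hold no one-place step of that kind. The value of compound 1 remains a limit and not a number, and it gives no step to any other compound shown: the limit of > 800000 nM in this assay, at which 1 of the 4 values shown sits.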